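Swapping bromo for methoxy on the indole-side aromatic ring

The source may hold more compounds than are shown below. What is called first, only, known or untested is meant among the compounds shown, and "the series" means these compounds.

Of the compounds shown here, three have been measured in a functional assay for inhibition, with a stated time of 5 min, tested at 1 mM; a higher number here means more inhibition at the concentration tested (going by the name of the read-out), a lower number less inhibition. Compound 1 `COc1ccc(/C(Cl)=C/C=C(\C#N)C(=O)c2c(C)[nH]c3ccccc23)cc1` gives 63.1% in this assay. Compound 2 `COc1ccc(/C(Cl)=C/C=C(\C#N)C(=O)c2c[nH]c3ccc(Br)cc23)cc1` gives 62.2%, the second highest of the three numbers; the number for compound 1 lies within the scatter of that for compound 2, so no order between the two can be read from these values. Compound 3 `COc1cc(/C(Cl)=C/C=C(\C#N)C(=O)c2c[nH]c3ccc(Br)cc23)cc(OC)c1OC` gives 50%, a number that lies beyond the scatter below compound 2. No pair among these three differs in only one place, so no single change has yet been followed on its own.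

The next compound, compound 4 `COc1ccc(/C(Cl)=C/C=C(\C#N)C(=O)c2c[nH]c3ccc(OC)cc23)cc1`, differs from compound 2 in one place: methoxy in place of bromo on an aromatic carbon. Going by the values given here, there is no measured pair showing what this exchange does in this assay, so the expectation rests on compound 2 alone and on the narrow spread between compound 1 and compound 2. The account therefore expects no step beyond the scatter, with a slight lean downward; the expected step from compound 2 to compound 4 is a number 4.2 percentage points lower from compound 2 to compound 4 (within the scatter). For compound 4 in this assay the estimated value is 58%, with a range from 42% to 72%.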

Compound 4, a percentage reported as inhibition, at one concentration (the size of the read-out at that concentration, not a potency): 60.7%
Compound 4: middle estimate off by 2.7 percentage points, on the low side, within the range that was stated.
By their numbers in this assay, from the lowest: compound 3; then compounds 4, 2 and 1 (each within the scatter of the next).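

Going by these compounds alone, this is the first single change that can be followed on its own, and methoxy in place of bromo gives a number 1.5 percentage points lower from compound 2 to compound 4 (within the scatter) in this assay at the one concentration tested. This place on the six-membered aromatic ring of the fused system therefore holds either bromo or methoxy without a step beyond the scatter, so the read-out does not separate these two groups, even though they differ in heavy atoms and hydrogen-bond acceptors. No measurement given here bears on why the two groups read alike.

The compounds shown leave open whether this place holds other kinds of group equally well, such as an amine, a carboxylic acid or a longer chain like butoxy, since bromo and methoxy are the only two compared here. They also leave open whether the exchange would read the same in the setting of compound 3, which carries bromo here, gives 50% in this assay and has no methoxy partner among these compounds.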